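The source may hold more compounds than are shown below. What is called first, only, known or untested is meant among the compounds shown, and "the series" means these compounds.

Of the compounds shown here, three that share one core have been measured in an in vitro functional assay on 1321-N1 cells for agonist activity at P2Y purinoceptor 4 (Homo sapiens), read by scintillation proximity assay and inositol phosphate accumulation; on this read-out lower numbers stand for an effect already at smaller amounts and higher numbers for an effect only at larger amounts of compound. Compound 1 `Nc1nc(=O)ccn1[C@@H]1O[C@H](COP(=O)(O)OP(=O)(O)O)[C@@H](O)[C@H]1O` carries an amino group on an aromatic carbon of the core; in this assay compound 1 reaches only the limit of >= 100000 nM, so no number is known for it. Compound 2 `CSc1nc(=O)ccn1[C@@H]1O[C@H](COP(=O)(O)OP(=O)(O)O)[C@@H](O)[C@H]1O` has methylsulfanyl in place of that amino and gives 1520 nM, a step of an at least 65-fold lower number from compound 1 to compound 2 (1.81 log units; beyond the scatter). Compound 3 `O=c1ccn([C@@H]2O[C@H](COP(=O)(O)OP(=O)(O)O)[C@@H](O)[C@H]2O)c(SCc2ccccc2)n1` has benzylsulfanyl in place of the amino and gives 5980 nM, a step of an at least 16-fold lower number from compound 1 to compound 3 (1.22 log units; beyond the scatter). Among the two real numbers, compound 3 stands highest; its nearest neighbour is compound 2, and the step of a 3.9-fold higher number from compound 2 to compound 3 (0.59 log units; beyond the scatter) separates them.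

Compound 4 `O=c1ccn([C@@H]2O[C@H](COP(=O)(O)OP(=O)(O)O)[C@@H](O)[C@H]2O)c(SCCc2ccccc2)n1` differs from compound 3 by benzyl in place of phenyl on a saturated chain carbon bound to a sulfur; the benzylsulfanyl thereby becomes phenethylsulfanyl. Going by the values given here, the one measured step that bears on this change is a 3.9-fold higher number from compound 2 to compound 3 (0.59 log units; beyond the scatter), where the phenyl added on the saturated chain carbon bound to sulfur made the number modestly higher. Extending the chain toward that phenyl once more is therefore expected to leave the number about where it is or push it a little higher, not lower. For compound 4 the estimate is 8000 nM with a range from 3000 nM to 25000 nM, which would mean an expected step of a 1.3-fold higher number from compound 3 to compound 4 (0.13 log units; within the scatter).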

Compound 4, half-maximal effective concentration: >= 100000 nM
Compound 4: only a limit was reported; the forecaster's own chance of this, stated with the estimate: 5%; at least 12-fold (1.09 log units) between middle value and limit.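

Compound 4 gives no number, only a limit of the assay: the limit of >= 100000 nM in this assay, at which 2 of the 4 values shown sit.

Even so, that limit shows how much this position responds to lengthening benzylsulfanyl to phenethylsulfanyl, with an at least 16-fold higher number from compound 3 to compound 4 (1.22 log units; beyond the scatter), and with an at least 65-fold higher number from compound 2 to compound 4 (1.81 log units; beyond the scatter), both larger than the earlier 3.9-fold higher number from compound 2 to compound 3 (0.59 log units; beyond the scatter). The earlier compounds shown here suggested only a modest change as the group on the sulfur grew from methylsulfanyl to benzylsulfanyl, whereas compound 4 shows a sharp drop-off in response to one further extension of the chain, with the step from compound 1 to compound 4 unreadable since a limit stands at both ends.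

Going by these compounds, how far beyond its limit the true value of compound 4 lies stays open, and so does the full size of its steps. The compounds shown also cannot separate the effect of chain length from that of the phenyl, which an ethylsulfanyl or propylsulfanyl group without a phenyl could help to tell apart.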